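EP3 acid linker series: estimate for compound 3

This account rests on a few compounds, and the source may have more. Where it says the series, first, only, none or still open, it means among the compounds named here.

Measured compounds:
compound 1 `O=C(O)C#Cc1ccc(Cn2cccn2)cc1OCCc1ccc2ccccc2c1`: 99 nM
compound 2 `O=C(O)COc1ccc(Cn2cccn2)cc1OCCc1ccc2ccccc2c1`: 260 nM

In an assay on CHO cells for displacement of a labelled ligand from prostaglandin E2 receptor EP3 subtype (Mus musculus), read by scintillation counting (on this read-out higher numbers stand for weaker inhibition and lower numbers for stronger inhibition), compound 2 gives 260 nM, the highest of the two numbers; compound 1 gives 99 nM, and the step of a 2.6-fold higher number from compound 1 to compound 2 (0.42 log units; beyond the scatter) is modest though beyond the scatter. Compound 3 `O=C(O)CCCc1ccc(Cn2cccn2)cc1OCCc1ccc2ccccc2c1` differs from compound 2 by 3-carboxypropyl in place of carboxymethoxy on an aromatic carbon. Within the data shown here, only that single step bears on the change, and it too alters the acid-bearing group in the same place, so a step of similar or smaller size in this assay is expected, with the direction uncertain. Compound 3 is estimated at 200 nM (range 60 nM to 700 nM), an expected step of a 1.3-fold lower number from compound 2 to compound 3 (0.11 log units; within the scatter).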

Compound 3, inhibition constant: 39 nM
The estimate for compound 3 lay 5.1-fold (0.71 log units) above the measured number; the measured number lies below the stated range.
By their numbers in this assay, from the lowest: compound 3; then compound 1; then compound 2.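

In this assay, replacing carboxymethoxy with 3-carboxypropyl gives a 6.7-fold lower number from compound 2 to compound 3 (0.82 log units; beyond the scatter) and shows that this position tolerates a longer acid-bearing chain. Replacing 2-carboxyethynyl with 3-carboxypropyl gives a 2.5-fold lower number from compound 1 to compound 3 (0.40 log units; beyond the scatter) as well, so compound 3 is the strongest of the three, with both of its steps beyond the scatter. The range across these acid-bearing groups is thus wider than the first pair indicated.

From the compounds shown here alone, whether 4-carboxybutyl or a tetrazole in place of the carboxylic acid would lower the number further remains open. Nothing available here explains the gain from 3-carboxypropyl.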